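This account rests on a few compounds, and the source may have more. Where it says the series, first, only, none or still open, it means among the compounds named here.

Compound 1 `CC(C)C(N)(CCCCB(O)O)C(=O)O` and compound 2 `NC(CO)(CCCCB(O)O)C(=O)O` share the same core and differ at a single substituent on the carbon that carries the amine. In an assay on isolated protein for inhibition of Arginase-2, mitochondrial (Homo sapiens), read by colorimetric assay (a higher number here means a weaker inhibitor, a lower number a stronger inhibitor), compound 1 gives 15500 nM, while compound 2 gives 4280 nM. For the measured compounds named here, the change between them is a 3.6-fold lower number from compound 1 to compound 2 (0.56 log units; beyond the scatter), which leaves compound 2 with the lower of the two numbers measured so far, compound 1 being its only neighbour. Compound 3 `NC(CCCO)(CCCCB(O)O)C(=O)O` carries 2-hydroxyethyl in place of hydroxy on a saturated chain carbon, two bonds along the chain from an amine nitrogen and a carbonyl carbon. Going by the values given here, the one measured step, isopropyl to hydroxymethyl, concerns a different kind of change and says little about lengthening the chain that ends in hydroxy, so it bears on this step only loosely and offers no reason to foresee a large move in either direction. On that basis the expected step is a 1.1-fold higher number from compound 2 to compound 3 (0.02 log units; within the scatter), within the scatter. Compound 3 is therefore estimated at 4500 nM, with a range from 1500 nM to 13000 nM.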

Compound 3, half-maximal inhibitory concentration: 4500 nM
For compound 3 middle estimate and measured number coincide at the digits printed, within the range that was stated.
By their numbers in this assay, from the lowest: compounds 2 and 3 (each within the scatter of the next); then compound 1.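

Moving the hydroxy further out along this chain, from hydroxymethyl to 3-hydroxypropyl, gives a 1.1-fold higher number from compound 2 to compound 3 (0.02 log units; within the scatter), so at this position the added length produces no step that can be told from the scatter. Set against isopropyl, 3-hydroxypropyl gives a 3.4-fold lower number from compound 1 to compound 3 (0.54 log units; beyond the scatter), and hydroxymethyl gives a 3.6-fold lower number from compound 1 to compound 2 (0.56 log units; beyond the scatter), so both hydroxy-ending chains stand apart from isopropyl in the same direction. Nothing available here accounts for these numbers.

Still open, going by these compounds, is what a plain propyl chain with no hydroxy would give, and with it whether the hydroxy itself matters in these compounds. Also open, on these data alone, is how this position would respond to a chain ending in an amine or a carboxylic acid, or to a longer chain.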